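The source may report more compounds than this note shows. Statements on the series, on what has been measured and on what is new or still open speak of the compounds shown alone.

In a functional assay on HeLa S3 cells (Homo sapiens) for cytotoxicity, read by XTT assay, with a stated time of 6 days (a lower number here means a stronger inhibitor, a higher number a weaker inhibitor), compound 1 `CN(C)c1ncnc2[nH]cc(Sc3cccs3)c12` gives > 25000 nM, which is a limit of the assay and not a number. Within the data shown here, compound 2 `CNc1ncnc2[nH]cc(Sc3cccs3)c12` gives 17600 nM, the only actual number so far. Compound 3 `Nc1ncnc2[nH]cc(Sc3cccs3)c12` differs from compound 2 as follows: hydrogen in place of methyl on a nitrogen on an aromatic ring, methylamino to amino. Among the measured compounds shown here, the one measured step of this kind is an at least 1.4-fold lower number from compound 1 to compound 2 (0.15 log units; that floor lies within the scatter), so it sets only a floor and its true size stays open. A modest move to a lower number in this assay is therefore expected, possibly none beyond the scatter. The expected change is a 1.6-fold lower number from compound 2 to compound 3 (0.20 log units; within the scatter). Compound 3 is estimated at 11000 nM, with an expected range of 3000 nM to 25000 nM.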

Compound 3, half-maximal inhibitory concentration: 17900 nM
Compound 3: the middle estimate sits 1.6-fold (0.21 log units) below what was measured; low and high end bracket the measured number.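

In this assay, the methylamino to amino change gives no measurable shift: a 1.0-fold higher number from compound 2 to compound 3 (0.01 log units; within the scatter). The amino and methylamino compounds therefore cannot be told apart at this position, and across the full change from dimethylamino to amino the step is an at least 1.3-fold lower number from compound 1 to compound 3 (0.14 log units; that floor lies within the scatter). Compound 1 stands at a limit and not a number, so that step sets only a floor: the limit of > 25000 nM in this assay, at which 1 of the 3 values shown sits.

As far as these compounds go, the true size of the step away from dimethylamino stays open. Also open, from the compounds shown here alone, is how a longer chain on this nitrogen, such as ethylamino or butylamino, or a carboxylic acid on the chain, would read in this assay.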